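Shortening the bromine-bearing chain by one carbon

This account rests on a few compounds, and the source may have more. Where it says the series, first, only, none or still open, it means among the compounds named here.

Compound 1, `COc1ccc(/C=C/c2cc(/C=C/c3ccc(OC)cc3)nc(OCCCCCBr)n2)cc1`, gives only a limit in a functional assay on NCI-H1299 cells (Homo sapiens) for cytotoxicity, read by fluorescence and resazurin assay, with a stated time of 48 h; a higher number here means a weaker inhibitor, a lower number a stronger inhibitor: > 20000 nM.
Compound 2, `COc1ccc(/C=C/c2cc(/C=C/c3ccc(OC)cc3)nc(OCCCCBr)n2)cc1`, gives only a limit in this assay: > 20000 nM.
Compound 3, `BrCCCCCCOc1nc(/C=C/c2ccccc2)cc(/C=C/c2ccccc2)n1`, gives only a limit in this assay: > 20000 nM.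

The change from compound 1 to compound 2 is bromo in place of bromomethyl on a saturated chain carbon, four bonds along the chain from an oxygen on an aromatic ring. Its size is a step that the two limits leave unreadable from compound 1 to compound 2. Compound 3 has a different core; the difference between the two cores is not broken down here. Compound 4, `BrCCCCCOc1nc(/C=C/c2ccccc2)cc(/C=C/c2ccccc2)n1`, is not yet measured. Its change from compound 3 is bromo in place of bromomethyl on a saturated chain carbon, five bonds along the chain from an oxygen on an aromatic ring. The place differs: four bonds along the chain in the first pair, five bonds in this one, so it is the same kind of change, not the same. Every value rests on (the limit of > 20000 nM in this assay, at which 3 of the 3 values shown sit). The step from compound 3 to compound 4 is expected to be a step that the limit leaves unreadable from compound 3 to compound 4 in this assay, since the measured pair gives no readable size. Compound 4 is expected to give 30000 nM, most likely again as a limit.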

Compound 4, half-maximal inhibitory concentration: > 20000 nM
Compound 4: a limit, no number; the forecaster's own chance of this, stated with the estimate: 85%; the middle value does not contradict the limit.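

The size of the step from compound 3 to compound 4 cannot be read, because both results are limits: the limit of > 20000 nM in this assay, at which 4 of the 4 values shown sit. The compounds shown leave open whether shortening the bromine-bearing chain changes cytotoxicity at all.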